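The source may hold more compounds than are shown below. What is called first, only, known or untested is meant among the compounds shown, and "the series" means these compounds.

The series shares one core, varied at a single ring position. Compound 1 `N#Cc1ccccc1-c1cnc(C(=O)CCCCCCc2ccccc2)o1` carries 2-cyanophenyl there, and in an assay (Rattus norvegicus) for inhibition of Fatty-acid amide hydrolase 1 (Homo sapiens) (on this read-out lower numbers stand for stronger inhibition and higher numbers for weaker inhibition), compound 1 gives 130 nM. Compound 2 `O=C(CCCCCCc1ccccc1)c1ncc(-c2nnn[nH]2)o1` carries 1H-tetrazol-5-yl at that position, and in this assay compound 2 gives 63 nM. The resulting step, a 2.1-fold lower number from compound 1 to compound 2 (0.31 log units; beyond the scatter), is modest. Among the compounds with values here, compound 2 thus shows the lower of the two numbers recorded, with compound 1 as its only neighbour.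

Compound 3 `CNC(=O)c1cnc(C(=O)CCCCCCc2ccccc2)o1` is not yet measured. It differs from compound 2 by methylcarbamoyl in place of 1H-tetrazol-5-yl on an aromatic carbon. Within the data shown here, only one measured step touches this position, a 2.1-fold lower number from compound 1 to compound 2 (0.31 log units; beyond the scatter), and it compares the tetrazole with an aryl nitrile rather than with a small amide, so it offers limited guidance on direction. Since that single step was modest, a similarly modest step in this assay is expected here, with the more likely direction toward a somewhat higher number: a 2.4-fold higher number from compound 2 to compound 3 (0.38 log units; beyond the scatter). Compound 3 is therefore estimated at 150 nM in this assay, with a range from 40 nM to 600 nM.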

Compound 3, inhibition constant: 7 nM
The estimate for compound 3 lay 21-fold (1.33 log units) above the measured number; the measured number lies below the stated range.
By their numbers in this assay, from the lowest: compound 3; then compound 2; then compound 1.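

In this assay the change to methylcarbamoyl gives a 9.0-fold lower number from compound 2 to compound 3 (0.95 log units; beyond the scatter) and also a 19-fold lower number from compound 1 to compound 3 (1.27 log units; beyond the scatter), so this position separates the compounds far more widely than the earlier comparison of 2-cyanophenyl with 1H-tetrazol-5-yl had shown. Compound 3 is also the only one of the three whose group at this position has no ring, and it has the lowest number, with its steps to both other compounds printed as beyond the scatter. Methylcarbamoyl and 1H-tetrazol-5-yl each count one hydrogen-bond donor and no net charge, so those counts do not distinguish them, while the ring, the heavy-atom makeup and the acceptor count all change together in this single step, and the three compounds cannot show which of these differences matters.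

Still open, going by these compounds, is whether the low number belongs to the methylcarbamoyl group specifically or would also appear with a carboxylic acid, an unsubstituted carboxamide, a dimethylcarbamoyl group or a longer chain on the amide nitrogen. Nothing available here bears on why this change lowers the number so strongly.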